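Aziridine-carbonitrile ureas: nitrogen substituent and cell inhibition

A few compounds are considered here, and "the series" means these few. Any claim that something is new, unique, unknown or untested is made for them only; others in the source may bear on it.

Compound 3 `CC(C)(C)NC(=O)N1CC1C#N` sits at the top of the three numbers in hand: in a functional assay on L1210 cells (Mus musculus) for inhibition, read by MTT assay (on this read-out higher numbers stand for weaker inhibition and lower numbers for stronger inhibition), compound 3 gives 457000 nM, compound 1 `CCCCNC(=O)N1CC1C#N` gives 12000 nM, and compound 2 `N#CC1CN1C(=O)Nc1ccc(F)cc1` gives 5900 nM. Compound 4 `CCNC(=O)N1CC1C#N` differs from compound 3 by ethyl in place of tert-butyl on an amide-type nitrogen. Among the measured compounds shown here, the one step that bears on this is a 38-fold higher number from compound 1 to compound 3 (1.58 log units; beyond the scatter), which shows that a branched group in that place carries a large penalty relative to a straight chain. Compound 4 returns to a straight chain, so a large drop in the number is expected, a 23-fold lower number from compound 3 to compound 4 (1.36 log units; beyond the scatter), toward the region of compound 1 because 12000 nM was measured with butyl there. Compound 4 is therefore estimated at 20000 nM, ranging from 5000 nM to 80000 nM.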

Compound 4, half-maximal inhibitory concentration: 14000 nM
Estimate against measurement, compound 4: 1.4-fold (0.15 log units) above; the measured number falls inside the stated range.
By their numbers in this assay, from the lowest: compound 2; then compounds 1 and 4 (each within the scatter of the next); then compound 3.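

In this assay, ethyl in place of tert-butyl on the amide-type nitrogen gives a large step (a 33-fold lower number from compound 3 to compound 4 (1.51 log units; beyond the scatter)), so the penalty carried by tert-butyl is lifted by a second straight chain and not by butyl alone. Ethyl and butyl are not separated at this position (a 1.2-fold higher number from compound 1 to compound 4 (0.07 log units; within the scatter)), so across these two straight chains the length makes no readable difference. Still open, going by these compounds, is how methyl, isopropyl or a longer chain such as octyl would read on the same nitrogen. No measurement in hand accounts for the size of either step.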